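The source may hold more compounds than are shown below. What is called first, only, known or untested is meant among the compounds shown, and "the series" means these compounds.

Measured compounds:
Compound 1 `NC(=O)c1c(NC(=O)c2ccccc2Cl)sc2c1CCN(C(=S)Nc1ccccc1Br)C2` gives 10800 nM in a functional assay on MKN-74 cells (Homo sapiens) for antiproliferative activity, with a stated time of 24 h; on this read-out higher numbers stand for weaker inhibition and lower numbers for stronger inhibition.
Compound 2 `NC(=O)c1c(NC(=O)c2ccccc2Cl)sc2c1CCN(C(=S)Nc1ccccc1I)C2` gives 2630 nM in this assay.
Compound 3 `Cc1ccccc1NC(=S)N1CCc2c(sc(NC(=O)c3ccccc3Cl)c2C(N)=O)C1` gives 11700 nM in this assay.

Among these three, compound 3 carries the highest number in this assay. Its nearest neighbour is compound 1: the step of a 1.1-fold higher number from compound 1 to compound 3 (0.03 log units; within the scatter) lies within the scatter, so the two cannot be ordered. Its furthest neighbour is compound 2: the step of a 4.4-fold higher number from compound 2 to compound 3 (0.65 log units; beyond the scatter) is modest but beyond the scatter.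

Compound 4 `NC(=O)c1c(NC(=O)c2ccccc2Cl)sc2c1CCN(C(=S)Nc1ccccc1-c1ccccc1)C2` differs from compound 3 in one place: phenyl in place of methyl on an aromatic carbon. Going by the values given here, two measured steps bear on this position. The step of a 4.1-fold lower number from compound 1 to compound 2 (0.61 log units; beyond the scatter) and the step of a 4.4-fold higher number from compound 2 to compound 3 (0.65 log units; beyond the scatter) both show that exchanging a small substituent for iodo at this carbon lowers the number modestly, whereas the step of a 1.1-fold higher number from compound 1 to compound 3 (0.03 log units; within the scatter) shows bromo and methyl to be indistinguishable there. Among the compounds with values here, no measured compound carries a ring at this position, so the direction for phenyl rests on the iodo cases only.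

Compound 4 is therefore expected to show a modest lowering, estimated as a 2.3-fold lower number from compound 3 to compound 4 (0.37 log units; beyond the scatter). The estimate for compound 4 is 5000 nM, with a range from 1500 nM to 16000 nM.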

Compound 4, half-maximal inhibitory concentration: 25800 nM
For compound 4 the middle estimate is 5.2-fold (0.71 log units) below the measured one; measured number above the stated range.
By their numbers in this assay, from the lowest: compound 2; then compounds 1 and 3 (each within the scatter of the next); then compound 4.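

In this assay the first ring at this aromatic carbon moves the number upward, both against methyl (a 2.2-fold higher number from compound 3 to compound 4 (0.34 log units; beyond the scatter)) and against bromo (a 2.4-fold higher number from compound 1 to compound 4 (0.38 log units; beyond the scatter)), so this position can also give weaker inhibition than either of those groups gave. The lowering seen with iodo does not carry over to phenyl: the gap between these two groups (a 9.8-fold higher number from compound 2 to compound 4 (0.99 log units; beyond the scatter)) is the widest step yet seen at this carbon, and compound 2 and compound 4 now mark the two ends of the four numbers. The compounds offer no measurement that would explain why iodo and phenyl part in this way.

As far as these compounds go, it remains open whether the rise belongs to phenyl itself or to rings at this carbon more generally, a question that a cyclohexyl or pyridyl group would address. From the compounds shown here alone, it is equally open how an amine, a carboxylic acid or a longer chain such as n-butyl would fare here, and whether any group at this carbon can reach a lower number than iodo does.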